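This account rests on a few compounds, and the source may have more. Where it says the series, first, only, none or still open, it means among the compounds named here.

Compound 1 `Nc1scc(CN2CCN(c3ccc(Cl)cc3Cl)CC2)c1C(=O)c1ccc(Cl)cc1` gives 0% in an assay on CHO cells for displacement of a labelled ligand from adenosine receptor A1 (Homo sapiens), read by scintillation counting, with a stated time of 120 min, tested at 10 uM; on this read-out higher numbers stand for more inhibition at the one concentration tested (going by the name of the read-out) and lower numbers for less inhibition; compound 2 `Nc1scc(CN2CCN(c3ccc(Cl)cc3F)CC2)c1C(=O)c1ccc(Cl)cc1` gives 0% in this assay.

Compound 2 stands level with compound 1 at the digits shown, and the one measured step, no change at the digits printed from compound 1 to compound 2 (within the scatter), lies within the scatter. Compound 3 `COc1ccc(N2CCN(Cc3csc(N)c3C(=O)c3ccc(Cl)cc3)CC2)cc1` differs from compound 2 by 4-methoxyphenyl in place of 4-chloro-2-fluorophenyl on an amine nitrogen in a ring. For the measured compounds named here, the only step measured so far bears on this change merely by analogy: it swapped one halogen for another on the same aromatic ring and moved nothing, whereas here the whole group on the ring nitrogen is exchanged for one carrying a hydrogen-bond acceptor, for which no measured pair exists. With both measured compounds showing no inhibition and no step beyond the scatter, the expected step of a number 5 percentage points higher from compound 2 to compound 3 (within the scatter) is none beyond the scatter. Compound 3 is therefore estimated at 5% in this assay, with a range from -10% to 25%.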

Compound 3, a percentage reported as inhibition, at one concentration (the size of the read-out at that concentration, not a potency): 0%
For compound 3 the middle estimate is 5 percentage points above the measured one; the range from low to high includes it.
By their numbers in this assay, from the lowest: compounds 1, 2 and 3 (each within the scatter of the next).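

In this assay, exchanging the whole group on the amine nitrogen in a ring, and not just one halogen on it, gives no change at the digits printed from compound 2 to compound 3 (within the scatter) and, against the dichlorinated compound, no change at the digits printed from compound 1 to compound 3 (within the scatter) in the same exchange of 2,4-dichlorophenyl for 4-methoxyphenyl. For the compounds shown here, at this position, then, a ring with no halogen that carries a hydrogen-bond acceptor reads the same as both halogenated rings, something the single halogen swap could not show. Nothing measured here offers an explanation for this unchanged reading.

The compounds shown leave open whether any group at this nitrogen would give a different reading, for instance a phenyl carrying a carboxylic acid or an amine, or a plain alkyl chain in place of the aromatic ring. They also leave open whether a change elsewhere on the shared core, such as an amide in place of its amine, would alter the reading.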